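Amide-tail changes and cell toxicity of thioester-linked benzamides

The compounds below may be only part of what the source reports. "The series", "measured", "known", "first", "only" and "open" are said of these compounds alone.

Three compounds sharing one core were tested in an ADME assay on CEM-SS cells (Homo sapiens) for cytotoxicity, read by XTT assay, with a stated time of 6 days; on this read-out lower numbers stand for higher toxicity in this test and higher numbers for lower toxicity in this test. Compound 1 `CCCC(=O)OCSc1ccccc1C(=O)NCCCC(N)=O` gives 56.6 uM. Compound 2 `CCCC(=O)OCSc1ccccc1C(=O)OCC(N)=O` gives 82.1 uM, and compound 3 `CCCC(=O)OCSc1ccccc1C(=O)N(C)CC(=O)N(C)C` gives 57.3 uM. The steps of a 1.5-fold higher number from compound 1 to compound 2 (0.16 log units; within the scatter) and a 1.0-fold higher number from compound 1 to compound 3 (0.01 log units; within the scatter) both stay within the scatter, so compound 1 stands among values that cannot be told apart from its own. Compound 4 `CCCC(=O)OCSc1ccccc1C(=O)NCC(=O)NCC(=O)OC` differs from compound 1 by ((methoxycarbonyl)methyl)carbamoyl in place of 2-carbamoylethyl on a saturated chain carbon bound to an amide-type nitrogen. Both measured steps that change the group on the carbonyl carbon left this assay unmoved, so the step of a 1.1-fold higher number from compound 1 to compound 4 (0.03 log units; within the scatter) is expected to be no larger than the scatter, in no fixed direction. Compound 4 is therefore estimated at 60 uM, with a range from 30 uM to 120 uM.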

Compound 4, half-maximal toxic concentration: > 100 uM
Compound 4: a limit, no number; the forecaster's own chance of this, stated with the estimate: 15%; middle value at least 1.6-fold (0.22 log units) from the limit.
By their numbers in this assay, from the lowest: compounds 1, 3 and 2 (each within the scatter of the next). At a limit, above all of these: compound 4.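

Going by these compounds alone, compound 4 is the first compound here whose reading is a limit and not a number: the limit of > 100 uM in this assay, at which 1 of the 4 values shown sits. Placing ((methoxycarbonyl)methyl)carbamoyl on a saturated chain carbon bound to an amide-type nitrogen gives an at least 1.7-fold higher number from compound 1 to compound 4 (0.24 log units; that floor lies within the scatter). Within the data shown here, this larger group therefore brings no sign of more toxicity in this assay, and it is the only change here that might move the number beyond the scatter, though its floor alone cannot show that.

From the compounds shown here alone, how far the true value of compound 4 lies past the limit stays open. So does the effect of a carboxylic acid or an amine in place of the methoxycarbonyl group.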